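The source may hold more compounds than are shown below. What is called first, only, known or untested is meant among the compounds shown, and "the series" means these compounds.

Compound 1 `O=C(Cn1cc(-c2ccc([N+](=O)[O-])cc2)nn1)Nc1nccs1` gives 1040 nM in a functional assay on BMDM cells (Mus musculus, strain C57BL/6) for inhibition, with a stated time of 2 days; a lower number here means a stronger inhibitor, a higher number a weaker inhibitor.
Compound 2 `O=C(Cn1cc(-c2ccc([N+](=O)[O-])cc2)nn1)Nc1nc2ccccc2s1` gives 3280 nM in this assay.

For the measured compounds named here, of the two numbers measured, compound 1 has the lower one; its nearest neighbour is compound 2, and the single measured step, a 3.2-fold higher number from compound 1 to compound 2 (0.50 log units; beyond the scatter), separates them. That step exchanges the ring on the amide-type nitrogen and leaves the rest of the shared core untouched.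

Compound 3 `C#Cc1ccc(-c2cn(CC(=O)Nc3nccs3)nn2)cc1` differs from compound 1 elsewhere: ethynyl in place of nitro on an aromatic carbon. The change sits on the six-membered aromatic ring of carbon only, a part of the molecule that the step from compound 1 to compound 2 did not touch. Going by the values given here, no measured step therefore bears on this exchange, and the data give no direction for it. On that basis the expected step in this assay is a 1.4-fold higher number from compound 1 to compound 3 (0.16 log units; within the scatter), that is, no change beyond the scatter, with a wide range to reflect the absence of any comparable step. Compound 3 is accordingly estimated at 1500 nM, between 400 nM and 6000 nM.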

Compound 3, half-maximal inhibitory concentration: > 30000 nM
Compound 3 ended at the assay's limit; the forecaster's own chance of this, stated with the estimate: 10%; at least 20-fold (1.30 log units) between middle value and limit.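

For the compounds shown here, the exchange on the six-membered aromatic ring gives an at least 28-fold higher number from compound 1 to compound 3 (1.46 log units; beyond the scatter), so this aromatic carbon, para to a large group, proves to be a place where the assay responds strongly, a part of the molecule on which the earlier compounds gave no information. This step is large, whereas the change on the amide-type nitrogen, a 3.2-fold higher number from compound 1 to compound 2 (0.50 log units; beyond the scatter), is modest, so among the steps shown, the exchange of nitro for ethynyl has the greater effect. In this assay compound 3 gives > 30000 nM, which is a limit of the assay and not a number: the limit of > 30000 nM in this assay, at which 1 of the 3 values shown sits.

As far as these compounds go, what stays open is whether the result reflects the departure of nitro or the arrival of ethynyl, as this single exchange cannot separate the two, and a nitrile or an amine on the same aromatic carbon would bear on that question. From the compounds shown here alone, it is also open whether the exchange would have a similar effect with 1,3-benzothiazol-2-yl on the amide-type nitrogen.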